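Oral exposure in rats: dihydrouracil to uracil on a stilbene

This account rests on a few compounds, and the source may have more. Where it says the series, first, only, none or still open, it means among the compounds named here.

Measured compounds:
- Compound 1 `COc1c(/C=C/c2ccc(NS(C)(=O)=O)cc2)cc(N2CCC(=O)NC2=O)cc1C(C)(C)C` — 1520 ng.h/mL
- Compound 2 `COc1c(C#Cc2ccc(NS(C)(=O)=O)cc2)cc(N2CCC(=O)NC2=O)cc1C(C)(C)C` — 350 ng.h/mL
- Compound 3 `COc1c(C(=O)Nc2ccc(NS(C)(=O)=O)cc2)cc(N2CCC(=O)NC2=O)cc1C(C)(C)C` — 50 ng.h/mL

In an ADME assay on the whole organism (strain Sprague-Dawley) for pharmacokinetics, with Rattus norvegicus as the target, at a dose of 5 mg/kg by the oral route (on this read-out lower numbers stand for lower exposure and higher numbers for higher exposure at the dose given), compound 1 gives 1520 ng.h/mL, the highest of the three numbers. Compound 2, the nearest, stands beyond the scatter below it, and compound 3 stands furthest below it, also beyond the scatter. For the measured compounds named here, these three compounds differ in the linker between the two aromatic rings, and no single-site step among them has been worked out.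

Compound 4 `COc1c(/C=C/c2ccc(NS(C)(=O)=O)cc2)cc(-n2ccc(=O)[nH]c2=O)cc1C(C)(C)C` keeps the linker of compound 1 and changes only the ring on the core: a group of 8 heavy atoms (4 carbon, 2 nitrogen, 2 oxygen; one six-membered aromatic ring with 2 hetero atoms) in place of a group of 8 heavy atoms (4 carbon, 2 nitrogen, 2 oxygen; one six-membered non-aromatic ring with 2 hetero atoms), on an aromatic carbon. Going by the values given here, with no measured pair of this kind to lean on, the size of the step in this assay is an open question. The expectation is a modest fall, a step from compound 1 to compound 4 of a 1.9-fold lower number from compound 1 to compound 4 (0.28 log units; within the scatter), which may or may not reach beyond the scatter. On that basis compound 4 is estimated to give 800 ng.h/mL, with a range from 250 ng.h/mL to 2500 ng.h/mL.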

Compound 4, area under the concentration-time curve in the Rattus norvegicus assay: 2520 ng.h/mL
Compound 4: middle estimate off by 3.2-fold (0.50 log units), on the low side; the whole stated range lies below it.
By their numbers in the Rattus norvegicus assay, from the lowest: compound 3; then compound 2; then compounds 1 and 4 (each within the scatter of the next).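

In the Rattus norvegicus assay, the six-membered aromatic ring in place of the six-membered non-aromatic ring, on the aromatic carbon para to a methoxy group, gives a 1.7-fold higher number from compound 1 to compound 4 (0.22 log units; within the scatter). The earlier compounds shown here differ only in their linker and say nothing about this position; this pair shows that, with the linker of compound 1 kept, this ring change leaves the oral exposure within the scatter. In a physicochemical assay for solubility, at pH 7.2 (on this read-out lower numbers stand for lower solubility and higher numbers for higher solubility), compound 1 gives 10300 nM and compound 4 gives 20700 nM, which is a 2.0-fold higher number from compound 1 to compound 4 (0.30 log units; within the scatter), so the two compounds also stand level on this second read-out, and nothing shown explains either result.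

As far as these compounds go, compound 2 and compound 3 carry only the non-aromatic ring, so it remains open whether the same ring change would leave exposure within the scatter with their linkers, where the numbers are much lower. From the compounds shown here alone, it is also open how a group of another kind at this position, such as a carboxylic acid, an amine or an open-chain urea, would behave in either read-out.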